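The compounds below may be only part of what the source reports. "The series", "measured", "known", "first", "only" and "open" are said of these compounds alone.

In an ADME assay on BJ cells (Homo sapiens) for cytotoxicity, read by CellTiter-Glo and resazurin assay, with a stated time of 72 h (on this read-out lower numbers stand for an effect already at smaller amounts and higher numbers for an effect only at larger amounts of compound), three compounds built on a shared core have been measured. Compound 1 (`CC(C)N(Cc1cccc(OCCCCCC(=O)O)c1)C(=O)c1ccc(-c2cccc3ccccc23)cc1`) gives < 1.3 nM, which is a limit of the assay. Compound 2 (`CC(C)N(Cc1cccc(OCCCCCC(=O)O)c1)C(=O)c1ccc(-c2ccoc2)cc1`) gives > 26000 nM, which is also a limit. Compound 3 (`CCOC(=O)CCCCCOc1cccc(CN(C(=O)c2ccc(-c3cccc4ccccc34)cc2)C(C)C)c1`) gives > 26000 nM, again only a limit. Compound 3 therefore stands at the limit of > 26000 nM in this assay, at which 2 of the 3 values shown sit.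

Compound 4 (`CCOC(=O)CCCCCOc1cccc(CN(C(=O)c2ccc(-c3cccnc3)cc2)C(C)C)c1`) keeps the ethyl ester of compound 3 and differs from it in one group: pyridin-3-yl in place of naphthalen-1-yl on an aromatic carbon. Going by the values given here, two measured steps bear on this change, and both are large and beyond the scatter. The first swaps the same naphthalen-1-yl for furan-3-yl and gives an at least 20000-fold higher number from compound 1 to compound 2 (4.30 log units; beyond the scatter). The second replaces hydrogen with ethyl and gives an at least 20000-fold higher number from compound 1 to compound 3 (4.30 log units; beyond the scatter). Both steps start from compound 1 and end at a limit, so neither gives a size for a step that starts from compound 3.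

Compound 4 carries the ethyl of the second step and, like compound 2, has lost the naphthalen-1-yl, so no return towards the low number of compound 1 is expected. The expected change is small, a step that the limit leaves unreadable from compound 3 to compound 4. For compound 4 the estimated value is 30000 nM, with an expected range from 15000 nM to 60000 nM, and it will most likely be reported as a limit again.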

Compound 4, half-maximal effective concentration: > 26000 nM
Compound 4 ended at the assay's limit; the forecaster's own chance of this, stated with the estimate: 85%; the middle value does not contradict the limit.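

In this assay, going by these compounds alone, compound 3 and compound 4 both end at a limit and not at a number, so no step between them can be read. The compounds shown leave open whether pyridin-3-yl in place of naphthalen-1-yl changes the read-out at all in the ethyl ester, and how large any such change would be.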